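A Fluoro Substituent on a Core Where Nothing Yet Registers

A few compounds are considered here, and "the series" means these few. Any claim that something is new, unique, unknown or untested is made for them only; others in the source may bear on it.

Compound 1 `CC1(C)Cc2c(OCc3ccccc3)ccc(C(=O)/C=C/c3ccccc3)c2O1`: > 100000 nM in a functional assay on NCI-H460 cells (Homo sapiens) for antiproliferative activity, read by MTT assay, with a stated time of 48 h (a lower number here means a stronger inhibitor, a higher number a weaker inhibitor), a limit of the assay rather than a number.
Compound 2 `CC1(C)Cc2c(ccc(C(=O)/C=C/c3ccc(Cl)cc3Cl)c2OCc2ccccc2)O1`: > 100000 nM in this assay, again only a limit.

Compound 1 stands at the limit itself; no number is known for it, and the same holds across the set, (the limit of > 100000 nM in this assay, at which 2 of the 2 values shown sit). Compound 3 `CC1(C)Cc2c(OCc3ccccc3)ccc(C(=O)/C=C/c3ccc(F)cc3)c2O1` differs from compound 1 by fluoro in place of hydrogen on an aromatic carbon. For the measured compounds named here, with no measured step to lean on, the change is expected to move little, a step that the limit leaves unreadable from compound 1 to compound 3, in no direction beyond the scatter. Compound 3 is therefore expected near 150000 nM, within 40000 nM to 600000 nM, most likely reported again as a limit.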

Compound 3, half-maximal inhibitory concentration: 22300 nM
The estimate for compound 3 lay 6.7-fold (0.83 log units) above the measured number; the measured number lies below the stated range.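

Phenyl to 4-fluorophenyl gives an at least 4.4-fold lower number from compound 1 to compound 3 (0.65 log units; beyond the scatter) in this assay, and compound 3 is the only compound shown with a number rather than a limit. This place, para to a large group, therefore responds to a single fluoro on the core of compound 1. The true size of the step stays unknown, since the value for compound 1 is only a limit: the limit of > 100000 nM in this assay, at which 2 of the 3 values shown sit.

Still open, from the compounds shown here alone, is whether the response is particular to fluoro, or whether chloro alone, methoxy or a nitrile at this place would lower the number as well.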